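Removing one methoxy group from compound 1

This account rests on a few compounds, and the source may have more. Where it says the series, first, only, none or still open, it means among the compounds named here.

Measured compounds:
- Compound 1 `COc1ccc(-n2cc(-c3cc(O)cc(O)c3)nn2)c(OC)c1`: in a functional assay on MDA-MB-231 cells (Homo sapiens) for cytotoxicity, read by MTT assay (a higher number here means a weaker inhibitor, a lower number a stronger inhibitor), compound 1 gives 10000 nM.
- Compound 2 `COc1ccc(-n2cc(-c3ccc(O)c(OC)c3)nn2)cc1`: compound 2 reaches only a limit of the assay, > 10000 nM.
- Compound 3 `COc1ccc(-c2cn(-c3ccc(OC(F)(F)F)cc3)nn2)cc1OC`: compound 3 likewise shows a limit of the assay, > 1000 nM.

Among the three results, compound 1 is the only one with an actual number; the other two sit at limits (the limit of > 1000 nM in this assay, at which 1 of the 3 values shown sits, and (the limit of > 10000 nM in this assay, at which 1 of the 3 values shown sits)), so compound 1 cannot be ranked against them with confidence. Its own value marks it as a weak inhibitor in this assay.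

Compound 4 `COc1ccc(-n2cc(-c3cc(O)cc(O)c3)nn2)cc1` shares the core of compound 1 and differs from it by hydrogen in place of methoxy on an aromatic carbon. Going by the values given here, no pair of measured compounds differing in one place is available, so the size of this step cannot be read from the data. With the result of compound 1 as the only anchor, the step is expected to stay within the usual scatter, in either direction. The expectation for compound 4 in this assay is 10000 nM, with a range from 4000 nM to 25000 nM. This estimate means a step of no change at the digits printed from compound 1 to compound 4 (within the scatter), that is, essentially none beyond the scatter.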

Compound 4, half-maximal inhibitory concentration: > 10000 nM
Compound 4 ended at the assay's limit; the forecaster's own chance of this, stated with the estimate: 50%; the middle value sits exactly at the limit.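

Going by these compounds alone, this is the first comparison of two compounds that differ in one place, here on an aromatic carbon ortho to a large group and meta to a methoxy group. In this assay, replacing the methoxy group with hydrogen gives a number no lower from compound 1 to compound 4 (the limit leaves the size open), so this change brings no gain in strength. The size of any loss cannot be read, and compound 4 stands at a limit, not at a number: the limit of > 10000 nM in this assay, at which 2 of the 4 values shown sit.

The compounds shown leave open whether the methoxy group at this position contributes to the activity of compound 1 at all, or whether its removal makes almost no difference. They also leave open whether an amine, a carboxylic acid or a longer chain at this position would give a lower number.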